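Methoxy in place of chloro on the shared core: compound 3

This account rests on a few compounds, and the source may have more. Where it says the series, first, only, none or still open, it means among the compounds named here.

Measured compounds, with an assay on cells for agonist activity at Neuronal acetylcholine receptor; alpha4/beta2 (Homo sapiens), read by patch clamp, with a stated time of 4 days; a higher number here means that more compound is needed for the effect, a lower number that less compound is needed:
Compound 1, `O=C(Nc1ccc(F)cc1)c1cncc(N2CC3CC(C2)N3)c1`, gives 520 nM.
Compound 2, `O=C(Nc1cccc(Cl)c1)c1cncc(N2CC3CC(C2)N3)c1`, gives 1000 nM.

Among the measured compounds shown here, compound 2 and compound 1 differ by a 1.9-fold higher number from compound 1 to compound 2 (0.28 log units; within the scatter), a step that lies within the usual scatter, so the two compounds stand together on the numbers so far; nothing separates them.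

Compound 3, `COc1cccc(NC(=O)c2cncc(N3CC4CC(C3)N4)c2)c1`, is the next member. Its change from compound 2 is methoxy in place of chloro on an aromatic carbon. For the measured compounds named here, the only measured step, from compound 1 to compound 2, exchanges 4-fluorophenyl for 3-chlorophenyl and does not touch a methoxy group, so no measured step bears directly on this change. Going by the values given here, the one comparison available shows that a change of substituent on this ring left this assay within scatter. On that basis compound 3 is expected to stay close to compound 2, with a step of no change at the digits printed from compound 2 to compound 3 (within the scatter) that is not expected to exceed the scatter in either direction. The estimate for compound 3 in this assay is 1000 nM, with a range from 400 nM to 2500 nM.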

Compound 3, half-maximal effective concentration: 600 nM
The estimate for compound 3 lay 1.7-fold (0.22 log units) above the measured number, within the range that was stated.
By their numbers in this assay, from the lowest: compounds 1, 3 and 2 (each within the scatter of the next).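

In this assay, the pair of compound 2 and compound 3 keeps the place on the ring fixed and exchanges only the group, and it gives a 1.7-fold lower number from compound 2 to compound 3 (0.22 log units; within the scatter) with no separation between 3-chlorophenyl and 3-methoxyphenyl. This holds although methoxy carries a hydrogen-bond acceptor that chloro lacks, so on these numbers that difference at this position goes with no step beyond the scatter. The comparison with the 4-fluorophenyl amide gives a 1.2-fold higher number from compound 1 to compound 3 (0.06 log units; within the scatter) and, as all three compounds stand within the scatter of one another, no order can be drawn among them, and nothing on hand accounts for this result.

Going by these compounds, whether an amine, a carboxylic acid or a longer chain such as butoxy at this place on the ring would move the number beyond the scatter stays open. Also open, on these data alone, is how chloro and methoxy would read at the position that holds fluoro in compound 1, and how far any change to the shared core would matter in this assay when the amide ring is held constant.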